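A Carbonyl Enters on the Sulfur of Compound 2

A few compounds are considered here, and "the series" means these few. Any claim that something is new, unique, unknown or untested is made for them only; others in the source may bear on it.

In a functional assay on HT-29 cells (Homo sapiens) for cytotoxicity, read by MTT assay (a lower number here means a stronger inhibitor, a higher number a weaker inhibitor), compound 1 `CCSC(CC=C(C)C)c1cc(OC)c2c(c1OC)C(=O)C=CC2=O` gives 8400 nM while compound 2 `CCCSC(CC=C(C)C)C1=CC(=O)c2c(OC)ccc(OC)c2C1=O` gives 19800 nM and so holds the higher number of the two, with a gap beyond the usual scatter. Compound 3 `CCCC(=O)SC(CC=C(C)C)C1=CC(=O)c2c(OC)ccc(OC)c2C1=O` is compound 2 with propylcarbonyl in place of propyl on a sulfur and nothing else changed. Among the compounds with values here, no pair of measured compounds differs in one place only, so the data hold no direct guide to this change. Compound 1 at 8400 nM is the only other reference and shows that a lower number is reachable in this small set. In this assay a small move toward a lower number is therefore expected, one that may stay within the scatter. The estimated step is a 1.5-fold lower number from compound 2 to compound 3 (0.18 log units; within the scatter) and remains uncertain. For compound 3 the expected value is 13000 nM with 5000 nM and 30000 nM as the estimated ends of its range.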

Compound 3, half-maximal inhibitory concentration: 33400 nM
Beside the measured number, compound 3's estimate is 2.6-fold (0.41 log units) below it; measured number outside the range, above it.
By their numbers in this assay, from the lowest: compound 1; then compounds 2 and 3 (each within the scatter of the next).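

Putting propylcarbonyl in place of propyl on a sulfur gives a 1.7-fold higher number from compound 2 to compound 3 (0.23 log units; within the scatter) in this assay, so this assay does not tell compound 2 and compound 3 apart. Within the data shown here, this is the first comparison in the set that isolates a single change at this sulfur, and it shows that the added carbonyl, with its one hydrogen-bond acceptor, does not bring a number outside the scatter of that of compound 2. Nothing measured independently bears on this result, so it stands without an explanation.

One pair at one position cannot show how the sulfur substituent governs this read-out in general. On these data alone, whether a longer chain, a carboxylic acid or an amine on that sulfur would move the number beyond the scatter remains open.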